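From compound 2 to compound 4: nitro for methoxy

A few compounds are considered here, and "the series" means these few. Any claim that something is new, unique, unknown or untested is made for them only; others in the source may bear on it.

Of the compounds shown here, three have been read so far in a functional assay on MCF7 cells (Homo sapiens) for antiproliferative activity, read by MTT assay, with a stated time of 72 h; a higher number here means a weaker inhibitor, a lower number a stronger inhibitor. Compound 1 `C=C1CN/C(=N/c2ccccc2)S1` gives > 100000 nM, which is a limit and not a number. Compound 3 `S=C(Nc1ccccc1)N1C/C(=C/c2ccccc2)S/C1=N\c1ccccc1` gives > 100000 nM, again a limit. Within the data shown here, compound 2 `COc1ccc(/C=C2/CN(C)/C(=N/c3ccc(OC)cc3)S2)cc1` gives 8700 nM, the only true number and so the sole anchor.

Compound 4 `COc1ccc(/C=C2/CN(C)/C(=N/c3ccc([N+](=O)[O-])cc3)S2)cc1` keeps everything in compound 2 except one group: nitro in place of methoxy on an aromatic carbon, para to a large group (nitro in place of methoxy on an aromatic carbon).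

Among the measured compounds shown here, no step between measured compounds sizes this kind of change, so the expectation is loose. It rests on compound 2 at 8700 nM and leans slightly towards weaker activity in this assay. The expected change is a 1.6-fold higher number from compound 2 to compound 4 (0.21 log units; within the scatter), an estimate not clearly beyond the usual scatter. For compound 4 the estimated value is 14000 nM, with an expected range from 4000 nM to 60000 nM.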

Compound 4, half-maximal inhibitory concentration: 9800 nM
The estimate for compound 4 lay 1.4-fold (0.15 log units) above the measured number; low and high end bracket the measured number.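

In this assay, the series now has its first readable step, at the aromatic carbon para to a large group: nitro in place of methoxy gives a 1.1-fold higher number from compound 2 to compound 4 (0.05 log units; within the scatter) and so leaves the two compounds reading alike. This pair therefore shows that methoxy at this position is not required to keep the activity seen with compound 2, and that an exchange of methoxy for nitro, with its extra heavy atom and double bond, passes without a change beyond the scatter. Compound 1 and compound 3 add no step to this reading, as their values are limits and not numbers: the limit of > 100000 nM in this assay, at which 2 of the 4 values shown sit.

Going by these compounds, whether an amine or a carboxylic acid at this position would read like methoxy and nitro remains open. Also open, on these data alone, is whether the methoxy kept by both compound 2 and compound 4 on the other aromatic ring can be exchanged as freely.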